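The source may hold more compounds than are shown below. What is called first, only, known or untested is meant among the compounds shown, and "the series" means these compounds.

Measured so far in the series:

compound 1, `COc1ccc(C(=O)NC(CCN(C)C)c2ccc(Cl)cc2)cc1`, 1350 nM
compound 2, `CN(C)CCC(NC(=O)c1ccc(C(F)(F)F)cc1)c1ccc(Cl)cc1`, 77.6 nM
compound 3, `COc1ccc(NC(=O)OC(CCN(C)C)c2ccc(Cl)cc2)cc1`, 1660 nM

All three numbers come from an assay on NIH3T3 cells with Urotensin-2 receptor (Homo sapiens) as the target; on this read-out lower numbers stand for an effect already at smaller amounts and higher numbers for an effect only at larger amounts of compound. Compound 1 and compound 2 share one core; compound 3 and the not yet measured compound 4, `CN(C)CCC(OC(=O)Nc1ccc(C(F)(F)F)cc1)c1ccc(Cl)cc1`, share another. The difference between the two cores is not broken down here. Within the first core the change trifluoromethyl in place of methoxy on an aromatic carbon gives a 17-fold lower number from compound 1 to compound 2 (1.24 log units; beyond the scatter). Compound 1 and compound 3 give numbers within the usual scatter of each other, while compound 2 lies beyond it from both.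

Compound 4 carries the same change on the second core, (trifluoromethyl in place of methoxy on an aromatic carbon), and the place is described in the same words as for compound 1 to compound 2, so it is the same change. The expected step for compound 4 is a 15-fold lower number from compound 3 to compound 4 (1.18 log units; beyond the scatter), set beside a 17-fold lower number from compound 1 to compound 2 (1.24 log units; beyond the scatter). Going by the values given here, because a 17-fold lower number from compound 1 to compound 2 (1.24 log units; beyond the scatter) is the only measured precedent and the core is another one, the range is kept wide. Compound 4 is estimated at 110 nM, expected between 30 nM and 450 nM.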

Compound 4, half-maximal effective concentration: 251 nM
The estimate for compound 4 lay 2.3-fold (0.36 log units) below the measured number, within the range that was stated.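

In this assay the change of trifluoromethyl in place of methoxy on an aromatic carbon also lowers the number on the second core, giving a 6.6-fold lower number from compound 3 to compound 4 (0.82 log units; beyond the scatter). The step has the same direction on both cores, and its size does not differ measurably between them: the same change on two cores in this assay, a 17-fold lower number (1.24 log units; beyond the scatter) from compound 1 to compound 2 and a 6.6-fold lower number (0.82 log units; beyond the scatter) from compound 3 to compound 4, 2.6-fold (0.42 log units) apart, within the scatter of two such steps. Going by these compounds alone, this supports carrying the change between these two cores, but with only two pairs it does not show that the step would hold on any further core, and it gives no reason for the lower number on either core.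

Still open is whether another group in the same place, such as a nitrile or an ethyl group, would follow trifluoromethyl, since only methoxy and trifluoromethyl appear there in the compounds shown. Also open, as far as these compounds go, is whether the step would persist on a related core carrying a carboxylic acid in place of the amine.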